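Shortening the Side Chain on the Ring Nitrogen

A few compounds are considered here, and "the series" means these few. Any claim that something is new, unique, unknown or untested is made for them only; others in the source may bear on it.

Measured compounds:
compound 1, `CC(C)(C)OC(=O)CCCN1CCc2c(sc(NC(=O)Nc3ccc(Cl)cc3)c2C(N)=O)C1`: 560 nM
compound 2, `NC(=O)c1c(NC(=O)Nc2ccc(Cl)cc2)sc2c1CCN(CCCNC(=O)CCc1cccnc1)C2`: 470 nM
compound 3, `CCN1CCc2c(sc(NC(=O)Nc3ccc(I)cc3)c2C(N)=O)C1`: 1620 nM

All three share one core and were tested in a functional assay (strain AB) with Danio rerio as the target, read by microscopy, with a stated time of 1 h; on this read-out lower numbers stand for an effect already at smaller amounts and higher numbers for an effect only at larger amounts of compound. Among these numbers compound 1 stands second highest: compound 2 is its nearest neighbour with a 1.2-fold lower number from compound 1 to compound 2 (0.08 log units; within the scatter), while compound 3 lies furthest away, giving a number that is beyond the scatter above that of compound 1.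

The new compound is compound 4, `CC(C)(C)OC(=O)N1CCc2c(sc(NC(=O)Nc3ccc(Cl)cc3)c2C(N)=O)C1`. Compared with compound 1 it carries tert-butoxycarbonyl in place of 3-(tert-butoxycarbonyl)propyl on an amine nitrogen in a ring. For the measured compounds named here, the only measured step that touches this part of the molecule is the one from compound 1 to compound 2, where the group at the far end of the chain was exchanged with almost no change in the read-out. Going by the values given here, no measured pair shows what happens when the chain itself is removed and a carbonyl-bearing group sits directly on the ring nitrogen, so the expectation for compound 4 rests on little. Among the compounds with values here, the change is expected to bring a 1.4-fold higher number from compound 1 to compound 4 (0.15 log units; within the scatter), that is, no step clearly beyond the scatter, but with wide uncertainty. Compound 4 is therefore estimated at 800 nM, within a range from 250 nM to 3000 nM.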

Compound 4, half-maximal effective concentration: > 25000 nM
Compound 4: a limit, no number (the forecaster's own chance of this, stated with the estimate: 10%); middle value at least 31-fold (1.49 log units) away from the limit.
By their numbers in this assay, from the lowest: compounds 2 and 1 (each within the scatter of the next); then compound 3. At a limit, above all of these: compound 4.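

In this assay, the substituent on the ring nitrogen proves far less forgiving than the earlier pair suggested. Exchanging the group at the far end of the chain gave a 1.2-fold lower number from compound 1 to compound 2 (0.08 log units; within the scatter), whereas putting tert-butoxycarbonyl in place of the whole 3-(tert-butoxycarbonyl)propyl group gives an at least 44-fold higher number from compound 1 to compound 4 (1.64 log units; beyond the scatter). Compound 4 gives no actual number in this read-out, only a limit of the assay: the limit of > 25000 nM in this assay, at which 1 of the 4 values shown sits. Both compounds carry the tert-butoxycarbonyl unit, so this step shows that the unit alone does not keep the effect within the measured range once the propyl chain is gone and the carbonyl sits directly on the ring nitrogen.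

This single step combines a shorter substituent with a different kind of attachment, so the compounds shown leave open which of the two matters. An acetyl group on the ring nitrogen would keep the carbonyl there, while a plain propyl chain or a two-carbon chain ending in the same ester would test the chain, and compound 3 cannot settle this since it also differs in its halogen.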